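The compounds below may be only part of what the source reports. "The series", "measured", "known", "first", "only" and "open" are said of these compounds alone.

Three compounds share one core and differ only in the amino group attached to it. All three have been tested in an ADME assay on MT4 cells (Homo sapiens) for cytotoxicity, read by MTT assay, with a stated time of 4 days; on this read-out lower numbers stand for higher toxicity in this test and higher numbers for lower toxicity in this test. Compound 1 `Cc1c(Cc2c(F)cccc2F)nc(N(C)C)[nH]c1=O`, with dimethylamino, reads > 89000 nM, which is a limit and not a number. Among the compounds with values here, compound 2 `Cc1c(Cc2c(F)cccc2F)nc(N(C)C(C)C)[nH]c1=O`, with an isopropyl(methyl)amino group, gives 79000 nM, the only actual number so far. Compound 3 `CCN(CC)c1nc(Cc2c(F)cccc2F)c(C)c(=O)[nH]1`, with diethylamino, reads > 81000 nM, which is also a limit. Compound 3 therefore has no exact position, and compound 1 is the other compound known only by a limit.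

Compound 4 `Cc1c(Cc2c(F)cccc2F)nc(N2CCC(C)CC2)[nH]c1=O` has not yet been measured. It carries 4-methylpiperidin-1-yl in place of diethylamino on an aromatic carbon, which brings in one six-membered non-aromatic ring.

The measured steps that bear on this also change the amino group. They are an at least 1.1-fold lower number from compound 1 to compound 2 (0.05 log units; that floor lies within the scatter), an at least 1.0-fold higher number from compound 2 to compound 3 (0.01 log units; that floor lies within the scatter) and a step that the two limits leave unreadable from compound 1 to compound 3. None of them shows a change beyond the scatter, although the limits hide how large the true steps are. A ring in this position has not been tested in this series, so the expectation remains loose. The expected change is an at least 1.2-fold lower number from compound 3 to compound 4 (0.09 log units; that floor lies within the scatter), which means no real shift in either direction. For compound 4 the estimated value in this assay is 65000 nM, with an expected range from 30000 nM to 90000 nM.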

Compound 4, half-maximal cytotoxic concentration: > 75000 nM
Compound 4 gave a limit, no number; the forecaster's own chance of this, stated with the estimate: 50%; middle value at least 1.1-fold (0.06 log units) from the limit.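

Within the data shown here, no step from compound 4 to compound 1, compound 2 or compound 3 can be read, because compound 4 is known only by a limit: the limit of > 75000 nM in this assay, at which 1 of the 4 values shown sits. The compounds shown leave open the actual values of compound 1, compound 3 and compound 4, and so whether 4-methylpiperidin-1-yl in place of diethylamino changes the read-out in this assay.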